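The source may report more compounds than this note shows. Statements on the series, on what has been measured and on what is new or still open speak of the compounds shown alone.

Of the compounds shown here, three that share one core have been tested so far in a functional assay on PC-3 cells (Homo sapiens) for antiproliferative activity, read by MTT assay, with a stated time of 48 h; a higher number here means a weaker inhibitor, a lower number a stronger inhibitor: compound 1 (`COc1ccc(CN(C(=O)CSc2ccccn2)c2cc(OC)c(OC)c(OC)c2)cc1`) gives 7510 nM, compound 2 (`COc1ccc(CN(C(=O)CCCSc2nc3ccccc3o2)c2cc(OC)c(OC)c(OC)c2)cc1`) gives 32700 nM, and compound 3 (`COc1ccc(CN(C(=O)CSc2nnnn2C)c2cc(OC)c(OC)c(OC)c2)cc1`) gives 10500 nM. Two steps show where compound 3 stands: a 1.4-fold higher number from compound 1 to compound 3 (0.15 log units; within the scatter), and a 3.1-fold lower number from compound 2 to compound 3 (0.49 log units; beyond the scatter). On these numbers, compound 3 stays level with compound 1 and sits apart from compound 2 on the stronger side.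

Compound 4 (`COc1ccc(CN(C(=O)CSc2nc3ccccc3o2)c2cc(OC)c(OC)c(OC)c2)cc1`) alters compound 3 at a single place, with 1,3-benzoxazol-2-yl in place of 1-methyl-1H-tetrazol-5-yl on a sulfur. Going by the values given here, the closest precedent is the other exchange made on that sulfur, a 1.4-fold higher number from compound 1 to compound 3 (0.15 log units; within the scatter), which stayed within the scatter. The larger steps, a 4.4-fold higher number from compound 1 to compound 2 (0.64 log units; beyond the scatter) and a 3.1-fold lower number from compound 2 to compound 3 (0.49 log units; beyond the scatter), replace the whole 2-((1,3-benzoxazol-2-yl)sulfanyl)ethyl group. They therefore cannot show how much of their size belongs to the 1,3-benzoxazol-2-yl alone, although they are a reason to keep the upper end of the range generous. No step beyond the scatter is expected. The estimated step is a 1.1-fold lower number from compound 3 to compound 4 (0.02 log units; within the scatter). In this assay, compound 4 is expected at about 10000 nM, within an estimated range of 3500 nM to 30000 nM.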

Compound 4, half-maximal inhibitory concentration: 3530 nM
Beside the measured number, compound 4's estimate is 2.8-fold (0.45 log units) above it; the range from low to high includes it.
By their numbers in this assay, from the lowest: compound 4; then compounds 1 and 3 (each within the scatter of the next); then compound 2.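

In this assay, the group on the sulfur turns out to matter, which the earlier exchange there, staying within the scatter, did not show: 1,3-benzoxazol-2-yl in place of 1-methyl-1H-tetrazol-5-yl gives a step beyond the scatter (a 3.0-fold lower number from compound 3 to compound 4 (0.47 log units; beyond the scatter)), and in place of pyridin-2-yl it gives another (a 2.1-fold lower number from compound 1 to compound 4 (0.33 log units; beyond the scatter)). Going by these compounds alone, the 1,3-benzoxazol-2-yl does not bring a low number on its own, since compound 2 carries the same group on a longer chain and the shortening of that chain to the one in compound 4 gives the widest gap seen so far (a 9.3-fold lower number from compound 2 to compound 4 (0.97 log units; beyond the scatter)). No evidence at hand gives a reason for either effect.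

The compounds shown do not tell whether an amine or a carboxylic acid carried on the 1,3-benzoxazol-2-yl would lower the number further or raise it again. Within the data shown here, they also leave open how the number behaves on a chain longer than the one in compound 2, and whether the two chain lengths seen here mark a trend at all.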